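Acrylamide series: pyrrolyl to phenyl on the chain carbon

The source may report more compounds than this note shows. Statements on the series, on what has been measured and on what is new or still open speak of the compounds shown alone.

Measured so far:
compound 1 `N#C/C(=C\c1ccc[nH]1)C(=O)NCc1ccc(Cl)c(Cl)c1` > 50000 nM
compound 2 `COc1ccc(CNC(=O)/C(C#N)=C/c2ccc(Cl)o2)cc1` 13000 nM

In a functional assay on SW480 cells (Homo sapiens) for inhibition, read by MTT assay, with a stated time of 72 h (on this read-out lower numbers stand for stronger inhibition of growth and higher numbers for weaker inhibition of growth), compound 1 gives only a limit, > 50000 nM, and no number. It therefore sits at the limit of > 50000 nM in this assay, at which 1 of the 2 values shown sits, the top end of what this assay reports. For the measured compounds named here, compound 2 gives a number, 13000 nM, in this assay; no step between compound 1 and compound 2 is laid out, as the two structures differ in more than one place.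

Compound 3 `N#C/C(=C\c1ccccc1)C(=O)NCc1ccc(Cl)c(Cl)c1` has not yet been tested. It differs from compound 1 in one place: phenyl in place of 1H-pyrrol-2-yl on a double-bonded chain carbon bound to a double-bonded chain carbon. Going by the values given here, no measured step bears on this change, so the size and direction of the step in this assay are open. With compound 1 at a limit, compound 3 is expected to stay weak, with the estimated step of an at least 1.4-fold lower number from compound 1 to compound 3 (0.15 log units; that floor lies within the scatter), and compound 3 is estimated at 35000 nM in this assay, within 8000 nM to 100000 nM.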

Compound 3, concentration for 50% growth inhibition: 49000 nM
The estimate for compound 3 lay 1.4-fold (0.15 log units) below the measured number; low and high end bracket the measured number.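

In this assay, phenyl in place of 1H-pyrrol-2-yl on a double-bonded chain carbon bound to a double-bonded chain carbon gives an at least 1.0-fold lower number from compound 1 to compound 3 (0.00 log units; that floor lies within the scatter). For the compounds shown here, this is the first step read at this position, and it shows that losing the ring hydrogen-bond donor of 1H-pyrrol-2-yl does not by itself give a gain beyond the scatter. The step can be read only as a floor, because compound 1 stands at a limit: the limit of > 50000 nM in this assay, at which 1 of the 3 values shown sits.

The true size of the step therefore stays open, since the compounds shown do not fix how far compound 1 lies past its limit. Also open, on these data alone, is whether a phenyl carrying an amine or a carboxylic acid at this place would shift the number in this assay beyond the scatter.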